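Trading an Indole for a Vinylphenyl on a Shared Core

The source may hold more compounds than are shown below. What is called first, only, known or untested is meant among the compounds shown, and "the series" means these compounds.

Three compounds share a core carrying a trimethoxyphenyl group and a second aromatic group. Compound 1 `COc1cc(-c2ccnc3c(-c4ccc(C)cc4)cnn23)cc(OC)c1OC` carries a methylphenyl group; in a functional assay on A549 cells (Homo sapiens) for inhibition, read by CCK-8 assay, with a stated time of 48 h (on this read-out higher numbers stand for weaker inhibition and lower numbers for stronger inhibition), compound 1 gives only a limit of > 10000 nM. Compound 2 `COc1cc(-c2cc3nccc(-c4c[nH]c5ccccc45)n3n2)cc(OC)c1OC` carries an indolyl group; in this assay compound 2 also gives only a limit of > 10000 nM. Among the compounds with values here, compound 3 `COc1cc(-c2ccnc3cc(-c4ccc5ccn(C)c5c4)nn23)cc(OC)c1OC` carries a 1-methyl-1H-indol-6-yl group and is the only compound with a number: in this assay compound 3 gives 829 nM. The other two sit at the limit (the limit of > 10000 nM in this assay, at which 2 of the 3 values shown sit).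

Compound 4 `C=Cc1ccc(-c2cc3nccc(-c4cc(OC)c(OC)c(OC)c4)n3n2)cc1` differs from compound 3 in one place (4-vinylphenyl in place of 1-methyl-1H-indol-6-yl on an aromatic carbon). The new group is smaller and carries no ring heteroatom. Within the data shown here, no measured step tells what such a change does here. Compound 4 is expected to inhibit more weakly than compound 3, by a 4.2-fold higher number from compound 3 to compound 4 (0.63 log units; beyond the scatter), probably beyond the usual scatter, with a real chance that only a limit is reported. Compound 4 is therefore estimated at 3500 nM, between 900 nM and 15000 nM.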

Compound 4, half-maximal inhibitory concentration: 1030 nM
Compound 4: middle estimate off by 3.4-fold (0.53 log units), on the high side; the measured number falls inside the stated range.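

In this assay, putting 4-vinylphenyl in place of 1-methyl-1H-indol-6-yl gives a 1.2-fold higher number from compound 3 to compound 4 (0.09 log units; within the scatter), so the two compounds cannot be told apart. At this aromatic carbon of the five-membered ring with 2 nitrogen, then, the two-ring indole group with its nitrogen is not required for activity at this level, as a single carbon-only aromatic ring bearing a vinyl group serves equally well. Compound 4 also gives a real number, joining compound 3, while the remaining compounds stay at the limit: the limit of > 10000 nM in this assay, at which 2 of the 4 values shown sit.

From the compounds shown here alone, whether the double bond of the vinyl group matters remains open, and a 4-ethylphenyl group at this position would test that. Also open, going by these compounds, is how this position responds to a group carrying a carboxylic acid or an amine on the phenyl ring.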